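Cytotoxicity at the limit: bromo to methyl

This account rests on a few compounds, and the source may have more. Where it says the series, first, only, none or still open, it means among the compounds named here.

Compound 1 `Cc1ccc(NCc2cn(-c3ccccc3)nc2-c2ccc(Cl)cc2)cc1`: > 100000 nM
Compound 2 `Brc1ccc(NCc2cn(-c3ccccc3)nc2-c2ccc(Br)cc2)cc1`: > 100000 nM

In an ADME assay on MDBK cells (Bos taurus) for cytotoxicity, read by MTT assay, with a stated time of 72 h (a lower number here means that less compound is tolerated, a higher number that more compound is tolerated), compound 2 gives > 100000 nM, which is a limit and not a number. Compound 1 gives > 100000 nM, also a limit. For the measured compounds named here, compound 2 therefore has no exact value, and the series so far sits at one level: the limit of > 100000 nM in this assay, at which 2 of the 2 values shown sit.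

Compound 3 `Cc1ccc(NCc2cn(-c3ccccc3)nc2-c2ccc(Br)cc2)cc1` has methyl in place of bromo on an aromatic carbon, para to a large group, so that (4-bromophenyl)amino becomes (4-methylphenyl)amino: methyl in place of bromo on an aromatic carbon. Going by the values given here, no measured step is available to size this change. In this assay no step beyond the scatter is expected, in either direction. This expectation rests on compound 1, which already carries the (4-methylphenyl)amino group and shows the limit > 100000 nM. The estimated change is a number no higher from compound 2 to compound 3 (the limit leaves the size open). The value expected for compound 3 is 100000 nM, within an estimated range of 50000 nM to 200000 nM, and a report as a limit is the likeliest outcome.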

Compound 3, half-maximal cytotoxic concentration: > 100000 nM
Compound 3: a limit, no number; the forecaster's own chance of this, stated with the estimate: 85%; the middle value sits exactly at the limit.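

In this assay no new step can be read: compound 3 is reported only as a limit, as are compound 1 and compound 2, and the steps among them cannot be sized. The compounds shown leave open where the true value of each lies, and whether exchanging bromo, chloro or methyl changes it at all.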